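The compounds below may be only part of what the source reports. "The series", "measured", "known", "first", "only" and "open" are said of these compounds alone.

Working notes on the series

Compound 3 `CCOC(=O)C1=C(Nc2ccccc2)S/C(=C\c2ccc[nH]2)C1=O` carries the shared core with a 1H-pyrrol-2-yl group on the double-bonded chain carbon. In a functional assay on A549 cells (Homo sapiens) for inhibition, read by MTT assay, with a stated time of 72 h, tested at 10 uM (a lower number here means less inhibition, a higher number more inhibition at the concentration tested (going by the name of the read-out)), compound 3 gives 23.5%. Compound 1 `CCOC(=O)C1=C(Nc2ccccc2)S/C(=C\c2ccc(Br)c(O)c2)C1=O`, with a 4-bromo-3-hydroxyphenyl group in the same place, gives 13.6% in this assay, and the step of a number 9.9 percentage points higher from compound 1 to compound 3 (within the scatter), so the two numbers cannot be told apart. Compound 2 `CCOC(=O)C1=C(Nc2ccccc2)S/C(=C\c2cccc(C(=O)O)c2)C1=O`, with a 3-carboxyphenyl group there, gives only a limit of this assay, < 10%, which is the limit of < 10% in this assay, at which 1 of the 3 values shown sits. From that limit the step of a number at least 13.5 percentage points higher from compound 2 to compound 3 (beyond the scatter), and a number at least 3.6 percentage points lower from compound 1 to compound 2 (that floor lies within the scatter).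

Compound 4 `CCOC(=O)C1=C(Nc2ccccc2)S/C(=C\c2cc3cccnc3[nH]2)C1=O` differs from compound 3 only at the same place: a group of 9 heavy atoms (7 carbon, 2 nitrogen; one five-membered aromatic ring with 1 hetero atom, one six-membered aromatic ring with 1 hetero atom) in place of a group of 5 heavy atoms (4 carbon, 1 nitrogen; one five-membered aromatic ring with 1 hetero atom), on a double-bonded chain carbon bound to a double-bonded ring carbon. For the measured compounds named here, no measured step shows this change; the three steps above all swap the whole group on the double-bonded chain carbon, and two of them stay within the scatter while the one beyond it starts from a limit. The change adds a six-membered aromatic ring with one hetero atom fused to the five-membered ring and keeps the single hydrogen-bond donor, so no step beyond the scatter is expected in this assay; a number 1.5 percentage points lower from compound 3 to compound 4 (within the scatter) is the expected step. Compound 4 is estimated at 22% in this assay, with a range from 5% to 42%.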

Compound 4, a percentage reported as inhibition, at one concentration (the size of the read-out at that concentration, not a potency): 16.7%
Beside the measured number, compound 4's estimate is 5.3 percentage points above it, within the range that was stated.
By their numbers in this assay, from the lowest: compounds 1, 4 and 3 (each within the scatter of the next). At a limit, below all of these: compound 2.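

At this position, the added six-membered aromatic ring with 1 hetero atom, which also brings 1 hydrogen-bond acceptor, does not separate the new group from the 1H-pyrrol-2-yl group in this assay: the reading is a number 6.8 percentage points lower from compound 3 to compound 4 (within the scatter). Set against the 4-bromo-3-hydroxyphenyl group, the same group gives a number 3.1 percentage points higher from compound 1 to compound 4 (within the scatter), so compound 1, compound 3 and compound 4 cannot be told apart here, although the groups on the double-bonded chain carbon differ in their rings and heavy atoms. Against the 3-carboxyphenyl group the reading is a number at least 6.7 percentage points higher from compound 2 to compound 4 (that floor lies within the scatter), so the new group does not repeat the clear separation seen with the 1H-pyrrol-2-yl group, and compound 2 remains a limit and not a number: the limit of < 10% in this assay, at which 1 of the 4 values shown sits.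

The compounds shown leave open what an amine or a longer chain on the double-bonded chain carbon would give in this assay. All the readings come from a single concentration, so any difference in potency among these groups also remains open.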